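The source may report more compounds than this note shows. Statements on the series, on what has been measured and on what is new or still open speak of the compounds shown alone.

Compound 2, `CCCCNc1nc(N)nc(C)c1CCc1ccccc1`, stands highest of the two numbers recorded so far in an assay on HEK293 cells for agonist activity at Toll-like receptor 8 (Homo sapiens), read by spectrophotometry (a higher number here means that more compound is needed for the effect, a lower number that less compound is needed), where compound 2 gives 1190 nM. Its nearest neighbour is compound 1, `CCCCNc1nc(N)nc(C)c1CCCN1C(=O)c2ccccc2C1=O`, for which the same assay gives 453 nM, a lower number that lies beyond the scatter. Compound 3, `CCCCNc1nc(N)nc(C)c1CCC(C)(C)O`, has not yet been measured. It differs from compound 2 in one place: 1-hydroxy-1-methylethyl in place of phenyl on a saturated chain carbon, two bonds along the chain from an aromatic carbon. For the measured compounds named here, no step between measured compounds matches this change, so there is nothing in the pair of compound 1 and compound 2 that speaks directly to it; those two differ elsewhere and only show that a change at this end of the chain can move the number beyond the scatter. Compound 3 is therefore expected to come out with a step from compound 2 that is modest, a 1.5-fold lower number from compound 2 to compound 3 (0.17 log units; within the scatter), likely toward a lower number but possibly no more than the scatter. The estimate for compound 3 is 800 nM, expected to fall between 300 nM and 2500 nM.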

Compound 3, half-maximal effective concentration: 3140 nM
Estimate against measurement, compound 3: 3.9-fold (0.59 log units) below; the whole stated range lies below it.
By their numbers in this assay, from the lowest: compound 1; then compound 2; then compound 3.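

In this assay, for the compounds shown here, putting 1-hydroxy-1-methylethyl in place of phenyl on this saturated chain carbon gives a 2.6-fold higher number from compound 2 to compound 3 (0.42 log units; beyond the scatter), the first change in one place on record at this position. It shows that the number here responds to the exchange of a six-membered aromatic ring of carbon only for an open group with a hydrogen-bond donor and acceptor, and that it moves upward, beyond the scatter. Nothing available gives a reason for this step.

Going by these compounds alone, the single step leaves the loss of the phenyl ring and the arrival of the hydroxyl tied together, and a cyclohexyl or tert-butyl group at this place would bear on that. Going by these compounds, how an amine, a carboxylic acid or a longer chain at this end would read remains open.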